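Nitro for methoxy on the aryl end of a dienone series

A few compounds are considered here, and "the series" means these few. Any claim that something is new, unique, unknown or untested is made for them only; others in the source may bear on it.

Compound 1 `COc1ccc(/C=C/C(=O)/C=C/C2=C(C)CCCC2(C)C)cc1` sits at a limit of a functional assay on Hep cells (Homo sapiens) for cytotoxicity, read by sulforhodamine B assay, with a stated time of 48 h; on this read-out lower numbers stand for stronger inhibition and higher numbers for weaker inhibition: the value > 100000 nM is a limit, not a number. Compound 2 `CC1=C(/C=C/C(=O)/C=C/c2ccc([N+](=O)[O-])cc2)C(C)(C)CCC1` gives 55500 nM in this assay. The step between them, (nitro in place of methoxy on an aromatic carbon), amounts to an at least 1.8-fold lower number from compound 1 to compound 2 (0.25 log units; that floor lies within the scatter), a floor that rests only on (the limit of > 100000 nM in this assay, at which 1 of the 3 values shown sits). Compound 3 `COc1ccccc1/C=C/C(=O)/C=C/C1=C(C)CCCC1(C)C` gives 38900 nM in this assay; its values and those of compound 2 lie within the scatter of each other. The difference between the cores of compound 3 and compound 1 is not broken down here.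

Compound 4 `CC1=C(/C=C/C(=O)/C=C/c2ccccc2[N+](=O)[O-])C(C)(C)CCC1` is unmeasured. It differs from compound 3 by nitro in place of methoxy on an aromatic carbon, the same kind of change as before, though the place is ortho to a large group rather than para to a large group. By analogy with the step of an at least 1.8-fold lower number from compound 1 to compound 2 (0.25 log units; that floor lies within the scatter) the expectation is a 1.6-fold lower number from compound 3 to compound 4 (0.19 log units; within the scatter), giving an estimated 25000 nM for compound 4 in this assay, between 8000 nM and 80000 nM.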

Compound 4, half-maximal inhibitory concentration: 44900 nM
The estimate for compound 4 lay 1.8-fold (0.25 log units) below the measured number; measured number inside the range.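

In this assay, nitro in place of methoxy, ortho to a large group, gives a 1.2-fold higher number from compound 3 to compound 4 (0.06 log units; within the scatter) for this pair. Set beside the earlier step, this neither shows that the change carries across the two cores nor shows that it fails to carry: the same change on two cores in this assay, an at least 1.8-fold lower number (0.25 log units; that floor lies within the scatter) from compound 1 to compound 2 and a 1.2-fold higher number (0.06 log units; within the scatter) from compound 3 to compound 4; the limit leaves it open whether they differ. Compound 1 stands at a limit, so the earlier step is only a floor and no size can be given for it: the limit of > 100000 nM in this assay, at which 1 of the 4 values shown sits.

Still open, on these data alone, is whether any aromatic substituent other than methoxy and nitro, such as an amine or a carboxylic acid, would give a step beyond the scatter. Also open, as far as these compounds go, is how a longer chain in place of the dienone linker would read.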